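Chloromethylbenzyl purines: from compound 2 to compound 4

The source may hold more compounds than are shown below. What is called first, only, known or untested is meant among the compounds shown, and "the series" means these compounds.

Measured so far:
compound 1 `Nc1nc(Cl)c2ncn(Cc3ccc(CCl)cc3)c2n1` — 38900 nM
compound 2 `ClCc1cccc(Cn2cnc3nc(Cl)nc(Cl)c32)c1` — "not determined" (no result reported)
compound 3 `ClCc1ccccc1Cn1cnc2c(Cl)nc(Cl)nc21` — "not determined" (no result reported)

Three compounds share a core and a benzyl group carrying a chloromethyl substituent. In a functional assay on SF-268 cells (Homo sapiens) for cytotoxicity, read by sulforhodamine B assay, with a stated time of 48 h (a higher number here means that more compound is tolerated, a lower number that less compound is tolerated), compound 1 gives 38900 nM. Compound 2 stands without a single number in this assay, its entry reading "not determined" (no result reported). Compound 3 is the one further entry that likewise has no number, its entry reading "not determined" (no result reported). For the measured compounds named here, nothing therefore connects compound 2 to compound 1 by a measured step, and no pair of measured compounds differs in only one place.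

The step considered here leads from compound 2 to compound 4 `ClCc1cccc(Cn2cnc3ncnc(Cl)c32)c1`, which is yet to be measured in this assay. The change is hydrogen in place of chloro on an aromatic carbon. Since compound 2 has no number, the size of this step cannot be derived from the data; in the absence of any measured step, the expectation is that it lies within the scatter of this assay, with no clear direction. Going by the values given here, the only anchor is compound 1 with 38900 nM, a compound of the same core and the same chloromethylbenzyl pattern. On that basis compound 4 is estimated at 40000 nM, expected to fall between 10000 nM and 150000 nM.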

Compound 4, concentration lethal to 50% of the cells: 47900 nM
Compound 4: middle estimate off by 1.2-fold (0.08 log units), on the low side; the measured number falls inside the stated range.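

For the compounds shown here, compound 4 adds no new step: compound 2, which differs from it by chloro in place of hydrogen, has no single number in this assay, and compound 1 and compound 4 do not form a one-place pair. The compounds shown leave open what that exchange does to the read-out. Nothing shown bears on a cause for the result.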